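The source may hold more compounds than are shown below. What is called first, only, known or untested is meant among the compounds shown, and "the series" means these compounds.

In a functional assay on RS4-11 cells (Homo sapiens) for inhibition, read by CCK-8 assay, with a stated time of 48 h, tested at 20 uM (a higher number here means more inhibition of growth at the concentration tested, a lower number less inhibition of growth), compound 1 `COc1ccc(Cc2nnc(NC(=O)/C(C#N)=C/c3ccccc3OS(=O)(=O)c3ccc(F)cc3)s2)cc1` gives 80%, compound 2 `N#C/C(=C\c1ccccc1OS(=O)(=O)c1ccc(F)cc1)C(=O)Nc1nnc(Cc2ccc(F)cc2)s1` gives 59% and compound 3 `Cc1ccc(S(=O)(=O)Oc2ccccc2/C=C(\C#N)C(=O)Nc2nnc(Cc3ccc(Cl)cc3)s2)cc1` gives 69%. Compound 3 therefore stands clearly under compound 1, while it cannot be told apart from compound 2.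

Compound 4 `N#C/C(=C\c1ccccc1OS(=O)(=O)c1ccc(F)cc1)C(=O)Nc1nnc(Cc2ccc(Cl)cc2)s1` differs from compound 3 in one group: fluoro in place of methyl on an aromatic carbon. In words, this is fluoro in place of methyl on an aromatic carbon, turning (4-methylphenyl)sulfonyl into (4-fluorophenyl)sulfonyl.

For the measured compounds named here, no measured pair shows this exact swap. The nearest evidence is a number 21 percentage points lower from compound 1 to compound 2 (beyond the scatter), a modest step in which fluoro also enters. However, fluoro replaces methoxy there, and at another place in the molecule, so that step is only a loose guide and says little about direction here. Compound 1 and compound 2 do carry the same (4-fluorophenyl)sulfonyl group as compound 4, and their values lie on either side of the value of compound 3.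

The data therefore give no reason to expect a change beyond the scatter. The expected step is small, a number 2 percentage points lower from compound 3 to compound 4 (within the scatter). For compound 4 the estimated value is 67%, with an expected range of 52% to 82%.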

Compound 4, percent growth inhibition at one concentration: 64%
For compound 4 the middle estimate is 3 percentage points above the measured one; the measured number falls inside the stated range.
By their numbers in this assay, from the lowest: compounds 2, 4 and 3 (each within the scatter of the next); then compound 1.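

In this assay, the first direct test at the sulfonyl end of the molecule gives a number 5 percentage points lower from compound 3 to compound 4 (within the scatter), so 4-methylphenyl and 4-fluorophenyl cannot be told apart there, at least with the 4-chlorobenzyl group in place on the other side. With (4-fluorophenyl)sulfonyl held fixed, the other end shows a number 5 percentage points higher from compound 2 to compound 4 (within the scatter), so chloro and fluoro on that aromatic carbon cannot be told apart either, whereas a number 16 percentage points lower from compound 1 to compound 4 (beyond the scatter) sets methoxy clearly above chloro, just as the earlier step set it above fluoro. Among these compounds, then, methoxy on that ring makes a readable difference, while the two halogens do not, and no measurement is available that would explain either finding.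

As far as these compounds go, the sulfonyl ring is covered here only by methyl and fluoro, so it remains open whether an amine or a carboxylic acid at that carbon would keep growth inhibition at a similar level. For the compounds shown here, at the other end, methoxy is the only group that is not a halogen, so an ethoxy group or a hydroxyl group could show whether the higher value extends beyond methoxy itself.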